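Turning the stereocentre of compound 3

A few compounds are considered here, and "the series" means these few. Any claim that something is new, unique, unknown or untested is made for them only; others in the source may bear on it.

Measured so far:
- compound 1 `C[C@H](NC1=NS(=O)(=O)c2cccnc2N1)c1ccccc1`: 65.2 uM
- compound 2 `C[C@H](NC1=NS(=O)(=O)c2cc(Cl)cnc2N1)C1CCCCC1`: 3.8 uM
- compound 3 `C[C@@H](NC1=NS(=O)(=O)c2cc(Cl)cnc2N1)c1ccccc1`: 38.8 uM

All three compounds share one core and were tested in a functional assay (aorta) with Rattus norvegicus as the target; on this read-out higher numbers stand for an effect only at larger amounts of compound and lower numbers for an effect already at smaller amounts. On that read-out compound 3 gives 38.8 uM. It sits at the high end together with compound 1, whose value of 65.2 uM lies within the usual scatter of compound 3, so the two cannot be told apart. Compound 2, with 3.8 uM, stands clearly apart from compound 3 at the low end, well beyond the scatter.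

Compound 4 `C[C@H](NC1=NS(=O)(=O)c2cc(Cl)cnc2N1)c1ccccc1` is not yet measured. The change from compound 3 to compound 4 is this: the two compounds have the same atoms and bonds and differ only in configuration as drawn: 1 of 1 stereo elements differ; a stereocentre at a saturated chain carbon is drawn R in compound 3 and S in compound 4. In words, the two compounds have the same atoms and bonds and differ only in configuration as drawn; a stereocentre at a saturated chain carbon is drawn R in compound 3 and S in compound 4.

Within the data shown here, no pair of measured compounds shows the effect of this change alone. Compound 2, which carries the S configuration and a cyclohexyl group, gives 3.8 uM; compound 1, also S but without the chlorine, gives 65.2 uM. Taken together these suggest a move toward lower numbers is more likely than the reverse, but the support is thin. In this assay compound 4 is expected to give about 12 uM, with a range from 2.5 uM to 60 uM. This estimate implies a step from compound 3 to compound 4 of a 3.2-fold lower number from compound 3 to compound 4 (0.51 log units; beyond the scatter).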

Compound 4, concentration for half-maximal effect: 21.2 uM
The estimate for compound 4 lay 1.8-fold (0.25 log units) below the measured number, within the range that was stated.
By their numbers in this assay, from the lowest: compound 2; then compounds 4, 3 and 1 (each within the scatter of the next, the first and the last beyond it).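

Among these compounds, compounds 3 and 4 form the first pair that isolates the stereocentre at the saturated chain carbon, and in this assay the step is small, a 1.8-fold lower number from compound 3 to compound 4 (0.26 log units; within the scatter), so the forms drawn R and S cannot be told apart here. No other structural change clouds this comparison: the fact that compounds 3 and 4 differ only in the configuration as drawn. Compound 4 also makes two other single changes readable, since phenyl in place of cyclohexyl gives a 5.6-fold higher number from compound 2 to compound 4 (0.75 log units; beyond the scatter) and chloro in place of hydrogen on an aromatic carbon gives a 3.1-fold lower number from compound 1 to compound 4 (0.49 log units; beyond the scatter); unlike the change of configuration, both steps lie beyond the scatter.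

The only pair of opposite configurations shown carries phenyl and chloro, so it remains open whether the stereocentre would matter as little with cyclohexyl on the chain carbon or without the chlorine. The compounds shown also leave open how a bromo or methoxy group in place of chloro, or a longer chain in place of phenyl or cyclohexyl, would read out on this aorta measurement.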